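Amide to Urea on the Shared Core: an Expected Gain

This account rests on a few compounds, and the source may have more. Where it says the series, first, only, none or still open, it means among the compounds named here.

Measured so far in a functional assay on NCI-H322M cells (Homo sapiens) for inhibition, read by sulforhodamine B assay, with a stated time of 48 h; a lower number here means a stronger inhibitor of growth, a higher number a weaker inhibitor of growth:
compound 1, `COc1cc(-c2nn(-c3cccc(NC(=O)c4ccc(Cl)c(C(F)(F)F)c4)c3)cc2-c2ccncc2)ccc1Cl`: 12800 nM
compound 2, `O=C(Nc1cccc(-n2cc(-c3ccncc3)c(-c3ccc(Cl)c(O)c3)n2)c1)Nc1cc(C(F)(F)F)cc(C(F)(F)F)c1`: 1310 nM

Of the two numbers, compound 1 stands highest, and so is the weaker growth inhibitor of the pair. Its nearest neighbour is compound 2, which gives a lower number, with a gap that lies beyond the usual scatter. Going by the values given here, the two compounds differ in more than one place, so no single step can be drawn between them; what they show is only that the urea of compound 2 comes with the lower number.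

Compound 3, `COc1cc(-c2nn(-c3cccc(NC(=O)Nc4ccc(Cl)c(C(F)(F)F)c4)c3)cc2-c2ccncc2)ccc1Cl`, is not yet measured. It differs from compound 1 in one place: (4-chloro-3-(trifluoromethyl)phenyl)amino in place of 4-chloro-3-(trifluoromethyl)phenyl on a carbonyl carbon. Among the compounds with values here, no measured pair isolates this change, so the expectation rests on what compound 2 shows beside compound 1. A moderate step towards a lower number is expected, a 2.8-fold lower number from compound 1 to compound 3 (0.45 log units; beyond the scatter), beyond the scatter but smaller than the gap to compound 2, since compound 2 carries further differences as well. Compound 3 is estimated at 4500 nM, with a range from 1500 nM to 12000 nM.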

Compound 3, concentration for 50% growth inhibition: 1500 nM
Compound 3: the middle estimate sits 3.0-fold (0.48 log units) above what was measured; the measured number falls inside the stated range.
By their numbers in this assay, from the lowest: compounds 2 and 3 (each within the scatter of the next); then compound 1.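

In this assay, the change on the carbonyl carbon now stands on its own on the shared core: with (4-chloro-3-(trifluoromethyl)phenyl)amino in place of 4-chloro-3-(trifluoromethyl)phenyl, the amide becomes a urea, and the result is an 8.5-fold lower number from compound 1 to compound 3 (0.93 log units; beyond the scatter). The earlier pair could only set a urea beside a lower number among several other differences, whereas this single replacement gives a step of this size with the rest of the structure held fixed. Nothing available here explains the step, so its cause stays unknown.

From the compounds shown here alone, it remains open whether the gain belongs specifically to the urea or would also appear with a thiourea, a carbamate or a methylated urea nitrogen on the same carbonyl position. Going by these compounds, it is also open whether the same replacement would give a step of similar size with other aryl groups on the urea, or on a version of the core carrying a hydroxyl in place of the methoxy group.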